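The compounds below may be only part of what the source reports. "The series", "measured", "known", "first", "only" and "open" are said of these compounds alone.

The shared core carries a chain ending in a hydroxyl-bearing carbon, and two such compounds have been measured. Compound 1 `OC(CCn1nc2c(Br)c(Br)c(Br)c(Br)c2n1)c1cccc(Cl)c1` was tested in a functional assay on MCF7 cells (Homo sapiens) for antiproliferative activity, read by MTT assay, with a stated time of 48 h, tested at 12.5 uM (a lower number here means a stronger effect, a higher number a weaker effect of the compound at the concentration tested), and gives 107%, the highest of the two numbers shown, although its nearest neighbour, compound 2 `C[C@H](O)CCn1nc2c(Br)c(Br)c(Br)c(Br)c2n1`, gives 100% in this assay, a gap that lies within the scatter of repeated measurements. Neither compound shows a meaningful effect at the concentration tested.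

Compound 3 `OC(CCn1nc2c(Br)c(Br)c(Br)c(Br)c2n1)c1ccc(F)cc1` has not yet been measured in this assay. It differs from compound 1 in one place: 4-fluorophenyl in place of 3-chlorophenyl on a saturated chain carbon bound to an oxygen on a saturated carbon and a saturated chain carbon. Within the data shown here, no step between two measured compounds that differ in a single place is available, so there is nothing against which to gauge the size of this change. The two measured compounds, which differ from each other in several places, sit at nearly the same level. The step from compound 1 to compound 3 is therefore expected to be a number 4 percentage points lower from compound 1 to compound 3 (within the scatter), a change not beyond the scatter in either direction. Compound 3 is estimated to give 103% in this assay, within a range from 90% to 116%.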

Compound 3, a percentage reported as activity, at one concentration (the size of the read-out at that concentration, not a potency): 109%
Compound 3: the middle estimate sits 6 percentage points below what was measured; the measured number falls inside the stated range.
By their numbers in this assay, from the lowest: compounds 2, 1 and 3 (each within the scatter of the next).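

In this assay, among these compounds, 4-fluorophenyl in place of 3-chlorophenyl on a saturated chain carbon bound to an oxygen on a saturated carbon and a saturated chain carbon gives a number 2 percentage points higher from compound 1 to compound 3 (within the scatter) and provides the only single-place comparison in this set. At this position, the two halogen-bearing phenyl groups therefore cannot be told apart by this read-out, and neither compound 1 nor compound 3 shows a meaningful effect at the concentration tested; since the halogen and its place on the ring differ together, the step cannot assign anything to either difference alone. Nothing measured for these compounds explains this result.

Going by these compounds, it remains open whether an amine or a carboxylic acid on the phenyl ring would shift the read-out from this level, or whether the phenyl group tolerates such a change as it does the exchange of halogens. Also open, on these data alone, is what a longer chain between the shared core and the hydroxyl-bearing carbon, or a carbonyl in place of that hydroxyl-bearing carbon, would do in this assay.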